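Solubility of a Chalcone Amide Series: Predicting Compound 4

The source may hold more compounds than are shown below. What is called first, only, known or untested is meant among the compounds shown, and "the series" means these compounds.

Of the compounds shown here, three sharing one core have been measured in a physicochemical assay for solubility, at pH 6.9; a lower number here means a less soluble compound, a higher number a more soluble compound. Compound 1 `O=C(CN1CCN(c2cc3c(cc2F)c(=O)c(C(=O)O)cn3C2CC2)CC1)Nc1ccc(C(=O)/C=C/c2ccccc2Cl)cc1` gives 2.45 ug/mL, compound 2 `O=C(CN1CCN(c2cc3c(cc2F)c(=O)c(C(=O)O)cn3C2CC2)CC1)Nc1ccc(C(=O)/C=C/c2cccc(Cl)c2)cc1` gives 34.4 ug/mL, and compound 3 `O=C(CN1CCN(c2cc3c(cc2F)c(=O)c(C(=O)O)cn3C2CC2)CC1)Nc1ccc(C(=O)/C=C/c2ccc(Cl)cc2)cc1` gives 2.77 ug/mL. Compound 3 thus stands second highest of the three; its value lies within the scatter of compound 1, while compound 2 sits far above it, as the step of a 12-fold lower number from compound 2 to compound 3 (1.09 log units; beyond the scatter) shows. The other steps, a 14-fold higher number from compound 1 to compound 2 (1.15 log units; beyond the scatter) and a 1.1-fold higher number from compound 1 to compound 3 (0.05 log units; within the scatter), complete the picture: only the 3-chlorophenyl compound stands apart.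

Compound 4 `COc1ccc(/C=C/C(=O)c2ccc(NC(=O)CN3CCN(c4cc5c(cc4F)c(=O)c(C(=O)O)cn5C4CC4)CC3)cc2)cc1OC` differs from compound 3 by 3,4-dimethoxyphenyl in place of 4-chlorophenyl on a double-bonded chain carbon bound to a double-bonded chain carbon. Going by the values given here, none of the measured steps exchanges chlorine for methoxy groups, so no step bears directly on this change; the measured steps only tell that moving a substituent on this ring can shift this assay strongly, as in a 12-fold lower number from compound 2 to compound 3 (1.09 log units; beyond the scatter), or hardly at all, as in a 1.1-fold higher number from compound 1 to compound 3 (0.05 log units; within the scatter). A modest rise from compound 3 to compound 4 is therefore expected, of size a 2.2-fold higher number from compound 3 to compound 4 (0.34 log units; beyond the scatter), though with wide uncertainty. Compound 4 is estimated at 6 ug/mL, within a range from 1.5 ug/mL to 25 ug/mL.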

Compound 4, solubility: 0.75 ug/mL
The estimate for compound 4 lay 8.0-fold (0.90 log units) above the measured number; measured number below the stated range.
By their numbers in this assay, from the lowest: compound 4; then compounds 1 and 3 (each within the scatter of the next); then compound 2.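

In this assay, the 3,4-dimethoxyphenyl group gives the lowest number of the series, with a 3.7-fold lower number from compound 3 to compound 4 (0.57 log units; beyond the scatter) and a 3.3-fold lower number from compound 1 to compound 4 (0.51 log units; beyond the scatter) both beyond the scatter, so the level shared by the 2-chlorophenyl and 4-chlorophenyl compounds is not the bottom of what this position can give. The gap to the 3-chlorophenyl compound is far wider, with a 46-fold lower number from compound 2 to compound 4 (1.66 log units; beyond the scatter) as the largest step in the set, which shows that exchanging the group on this double-bonded chain carbon can move the number further than moving a single chlorine around the ring did. No measurement shown here accounts for the fall.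

On these data alone, the two methoxy groups enter together, so it remains open whether a 3-methoxyphenyl or a 4-methoxyphenyl group alone would give a number nearer compound 4 or nearer compound 2, and thus whether the high number of compound 2 is tied to chlorine or extends to other groups at that ring position. As far as these compounds go, it is also open how a ring carrying a dimethylamino group or a carboxylic acid would read at this place.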